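Changing the Amide Arm on a Shared Quinazoline-Free Core

The compounds below may be only part of what the source reports. "The series", "measured", "known", "first", "only" and "open" are said of these compounds alone.

Compound 1 `CCN(CC)C(=O)C1CCN(c2nc(N)c3cc(OC)c(OC)cc3n2)CC1` is the weaker of the two measured compounds in an assay on isolated protein for displacement of a labelled ligand from Adrenergic receptor alpha-1 (Rattus norvegicus) (a lower number here means a stronger inhibitor, a higher number a weaker inhibitor), giving 1.11 nM. Compound 2 `COc1cc2nc(N3CCC(C(=O)N(C)Cc4ccccc4)CC3)nc(N)c2cc1OC` gives 0.2 nM. Among the measured compounds shown here, the one step that bears here, a 5.6-fold lower number from compound 1 to compound 2 (0.74 log units; beyond the scatter), shows that reworking the group on the carbonyl carbon can shift the number beyond the scatter. Compound 3 `COc1cc2nc(N3CCC(CC(=O)NCC4CC4)CC3)nc(N)c2cc1OC` carries a different reworking of that same region: ((cyclopropylmethyl)carbamoyl)methyl in place of diethylcarbamoyl on a saturated ring carbon. For the measured compounds named here, with only that one related step, the expectation for compound 3 is a modest change toward a lower number, a 1.6-fold lower number from compound 1 to compound 3 (0.20 log units; within the scatter), giving an estimated 0.7 nM with a range from 0.2 nM to 3 nM.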

Compound 3, inhibition constant: 1.08 nM
The estimate for compound 3 lay 1.5-fold (0.19 log units) below the measured number; the range from low to high includes it.
By their numbers in this assay, from the lowest: compound 2; then compounds 3 and 1 (each within the scatter of the next).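

this assay records a 1.0-fold lower number from compound 1 to compound 3 (0.01 log units; within the scatter) for this swap on a saturated ring carbon, so not every reworking of this region moves the number beyond the scatter. The entering group brings a three-membered ring and a hydrogen-bond donor that diethylcarbamoyl lacks, and the two compounds still stand level. Nothing available explains this level result.

The compounds shown do not separate the effect of the cyclopropylmethyl group from that of the added carbon leading to the carbonyl. Going by these compounds, how a carboxylic acid on this ring carbon would read in this assay also remains open.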